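Trimethoxyphenyl analogue: expected cytotoxicity on A549 cells

This account rests on a few compounds, and the source may have more. Where it says the series, first, only, none or still open, it means among the compounds named here.

Compound 2 `COc1ccc2nc(NC(=O)c3cc(-c4ccc(OC)c(OC)c4)n4nc(-c5ccccc5)cc4n3)sc2c1` carries a 3,4-dimethoxyphenyl group on the shared core. In a functional assay on A549 cells (Homo sapiens) for cytotoxicity, read by MTT assay, with a stated time of 48 h (a higher number here means a weaker inhibitor, a lower number a stronger inhibitor), compound 2 gives 15800 nM. Among the measured compounds shown here, its only comparator is compound 1 `COc1ccc2nc(NC(=O)c3cc(-c4ccc(F)cc4)n4nc(-c5ccccc5)cc4n3)sc2c1`, the 4-fluorophenyl analogue, which in this assay gives 24000 nM; the step of a 1.5-fold lower number from compound 1 to compound 2 (0.18 log units; within the scatter) lies within the scatter, so the two numbers cannot be ordered and compound 2 simply holds the lower of the two. Compound 3 `COc1ccc2nc(NC(=O)c3cc(-c4cc(OC)c(OC)c(OC)c4)n4nc(-c5ccccc5)cc4n3)sc2c1` is the next member: methoxy in place of hydrogen on an aromatic carbon, or, read one bond further out, 3,4-dimethoxyphenyl becomes 3,4,5-trimethoxyphenyl. For the measured compounds named here, the one step that bears on this, a 1.5-fold lower number from compound 1 to compound 2 (0.18 log units; within the scatter), exchanged the whole aryl substitution pattern without moving the number beyond the scatter. Going by the values given here, a single added methoxy is a smaller change, and no measured step goes beyond the scatter. The expectation for compound 3 in this assay is therefore no step beyond the scatter, a 1.2-fold lower number from compound 2 to compound 3 (0.08 log units; within the scatter). Compound 3 is estimated at 13000 nM, with a range of 6000 nM to 30000 nM.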

Compound 3, half-maximal inhibitory concentration: 2810 nM
For compound 3 the middle estimate is 4.6-fold (0.67 log units) above the measured one; the measured number lies below the stated range.
By their numbers in this assay, from the lowest: compound 3; then compounds 2 and 1 (each within the scatter of the next).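

In this assay, among the compounds shown here, the aryl position on the shared core proves sensitive to a single added methoxy, ortho to a methoxy group, which gives a 5.6-fold lower number from compound 2 to compound 3 (0.75 log units; beyond the scatter) and is the first step to lie beyond the scatter. The replacement of 4-fluorophenyl by 3,4,5-trimethoxyphenyl gives an 8.5-fold lower number from compound 1 to compound 3 (0.93 log units; beyond the scatter), whereas the earlier exchange for 3,4-dimethoxyphenyl, a 1.5-fold lower number from compound 1 to compound 2 (0.18 log units; within the scatter), stayed within the scatter, so among these three compounds only the 3,4,5-trimethoxyphenyl group stands apart. No supporting data accompany these numbers to account for the size of the step.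

Still open, from the compounds shown here alone, is whether the step is tied to methoxy itself, which a hydroxy group, an amine or a longer chain such as ethoxy in place of the added methoxy would test. Also open, going by these compounds, is whether the same step would appear with the phenyl group on the far side of the shared core replaced, for example by a pyridine ring or a carboxylic acid-bearing phenyl group.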